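This account rests on a few compounds, and the source may have more. Where it says the series, first, only, none or still open, it means among the compounds named here.

The measured compounds and their values:

Compound 1 `O=[N+]([O-])c1ccc2c(c1)N(S(=O)(=O)c1ccc(-c3cnc(C4CC4)o3)cc1)CCCO2`: in a functional assay on SK-OV-3 cells (Homo sapiens) for antiproliferative activity, read by MTT assay, with a stated time of 72 h (a higher number here means a weaker inhibitor, a lower number a stronger inhibitor), compound 1 gives 53 nM.
Compound 2 `COc1ccc2c(c1)N(S(=O)(=O)c1ccc(-c3cnc(C4CC4)o3)cc1)CCCO2`: in this assay compound 2 gives 53 nM.
Compound 3 `O=S(=O)(c1ccc(-c2cnc(C3CC3)o2)cc1)N1CCCOc2ccc(Cl)cc21`: in this assay compound 3 gives 19 nM.

Among these three numbers compound 3 has the lowest, which in this assay means the strongest inhibitor of the three. The change from compound 1 to compound 3, chloro in place of nitro on an aromatic carbon, gave a 2.8-fold lower number from compound 1 to compound 3 (0.45 log units; beyond the scatter), and the change from compound 2 to compound 3, chloro in place of methoxy on an aromatic carbon, gave a 2.8-fold lower number from compound 2 to compound 3 (0.45 log units; beyond the scatter). Between compound 1 and compound 2, methoxy in place of nitro on an aromatic carbon, there was no change at the digits printed from compound 1 to compound 2 (within the scatter).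

Compound 4 `Cc1ccc2c(c1)N(S(=O)(=O)c1ccc(-c3cnc(C4CC4)o3)cc1)CCCO2` differs from compound 3 by methyl in place of chloro on an aromatic carbon. For the measured compounds named here, no measured step here involves a methyl, so none bears directly on this change. The two steps that end at compound 3 show that a chloro on this aromatic carbon gave a lower number than either a nitro or a methoxy there; a methyl is none of these, so the direction is uncertain. A modest step is expected, drifting back toward the numbers of compound 1 and compound 2, though it may well stay within the scatter. The expected step from compound 3 to compound 4 is a 1.8-fold higher number from compound 3 to compound 4 (0.27 log units; within the scatter). Compound 4 is estimated to give 35 nM, within a range from 15 nM to 80 nM.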

Compound 4, half-maximal inhibitory concentration: 34 nM
The estimate for compound 4 lay 1.0-fold (0.01 log units) above the measured number; the range from low to high includes it.
By their numbers in this assay, from the lowest: compounds 3, 4, 1 and 2 (each within the scatter of the next, the first and the last beyond it).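

In this assay methyl in place of chloro gives a 1.8-fold higher number from compound 3 to compound 4 (0.25 log units; within the scatter) while methyl in place of methoxy gives a 1.6-fold lower number from compound 2 to compound 4 (0.19 log units; within the scatter) and methyl in place of nitro gives a 1.6-fold lower number from compound 1 to compound 4 (0.19 log units; within the scatter) so compound 4 cannot be told apart from any of the other three compounds. The earlier compounds shown here made chloro look set apart from nitro and methoxy, but with methyl at this aromatic carbon the four groups form a run of small steps in which only compound 3 against compound 1 and compound 3 against compound 2 lie beyond the scatter, even though chloro and methyl match in what was counted: one heavy atom each, no ring and no hydrogen-bond donors or acceptors. Nothing measured here accounts for these numbers.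

Whether an ethyl or a longer chain, an amine or a carboxylic acid at this aromatic carbon would stay among these numbers remains open. The compounds shown also vary only this one place, so they say nothing about how changes elsewhere on the shared core would behave.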